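Notes on the step from compound 3 to compound 4

The compounds below may be only part of what the source reports. "The series", "measured", "known", "first", "only" and "open" are said of these compounds alone.

The series has three measured entries so far. For compound 1 `Nc1nc(-c2ccccn2)nn1-c1ncnc2cc(N3CCNCC3)c([N+](=O)[O-])cc12`, the entry in an ADME assay on BJ cells (Homo sapiens) for cytotoxicity, with a stated time of 72 h (on this read-out higher numbers stand for an effect only at larger amounts of compound and lower numbers for an effect already at smaller amounts), reads "not determined" (no result reported). Compound 2 `COCCOc1cc2ncnc(-n3nc(-c4ccccn4)nc3N)c2cc1OCCOC` gives > 27000 nM, which is a limit and not a number. Compound 3 `COCCOc1cc2c(-n3nc(-c4ccccn4)nc3N)ncnc2cc1OC` gives > 13000 nM, which is also a limit and not a number. Compound 3 therefore has no exact position on this read-out.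

Compound 4 `COc1cc2ncnc(-n3nc(-c4ccccn4)nc3N)c2cc1OCCCNC(=O)OCC(F)(F)F` is derived from compound 3 by placing (((2,2,2-trifluoroethoxy)carbonyl)amino)methyl in place of methoxy on a saturated chain carbon, two bonds along the chain from an oxygen on an aromatic ring. Cut one bond further out, the same difference reads 2-methoxyethyl to 3-(((2,2,2-trifluoroethoxy)carbonyl)amino)propyl.

Among the compounds with values here, only one measured step changes this part of the structure: a step that the two limits leave unreadable from compound 2 to compound 3. It places hydrogen in place of methoxymethyl on a saturated chain carbon bound to an oxygen on an aromatic ring. Within the data shown here, it gives neither a size nor a direction, and the entering group has no measured precedent.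

No change beyond the scatter is therefore expected in this assay, and the expected step is a step that the limit leaves unreadable from compound 3 to compound 4. For compound 4 the estimate is 20000 nM, with an expected range from 5000 nM to 60000 nM.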

Compound 4, half-maximal effective concentration: > 11000 nM
Compound 4 gave a limit, no number; the forecaster's own chance of this, stated with the estimate: 65%; the middle value lies beyond the limit too.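

In this assay compound 4 gives > 11000 nM, which is a limit and not a number. Compound 3 gives > 13000 nM, which is also a limit. The step between compound 3 and compound 4 therefore cannot be read. The compounds shown leave open at what concentration, if any, compound 3 and compound 4 produce an effect on these cells.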